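This account rests on a few compounds, and the source may have more. Where it says the series, first, only, none or still open, it means among the compounds named here.

Measured so far in a functional assay on SK-BR-3 cells (Homo sapiens) for antiproliferative activity, read by MTT assay, with a stated time of 72 h; a lower number here means a stronger inhibitor, a higher number a weaker inhibitor:
- Compound 1 `C/C=C1/[C@H](O[C@@H]2O[C@H](CO)[C@@H](O)[C@H](O)[C@H]2O)OC=C(C(=O)OC)[C@H]1CC(=O)OCc1ccc(OC)c(OC)c1`: > 15000 nM (a limit)
- Compound 2 `C/C=C1/[C@H](O[C@@H]2O[C@H](CO)[C@@H](O)[C@H](O)[C@H]2O)OC=C(C(=O)OC)[C@H]1CC(=O)OCCc1ccc([N+](=O)[O-])cc1`: > 20000 nM (a limit)

Compound 2 gives > 20000 nM in this assay, which is a limit and not a number. Compound 3 `C/C=C1/[C@H](O[C@@H]2O[C@H](CO)[C@@H](O)[C@H](O)[C@H]2O)OC=C(C(=O)OC)[C@H]1CC(=O)OCCC(C)C` carries isopropyl in place of 4-nitrophenyl on a saturated chain carbon, two bonds along the chain from an oxygen next to a carbonyl group.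

Going by the values given here, the one measured step that bears on this change is a step that the two limits leave unreadable from compound 1 to compound 2. It gives no usable size, so no step beyond the scatter can be expected on the evidence available. Compound 3 is therefore expected to stay in the same weak region, and a limit is the likeliest result. The expected step is a step that the limit leaves unreadable from compound 2 to compound 3. For compound 3 the estimate is 25000 nM, with an expected range from 10000 nM to 60000 nM.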

Compound 3, half-maximal inhibitory concentration: 9020 nM
Estimate against measurement, compound 3: 2.8-fold (0.44 log units) above, and the stated range ends above it.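

In this assay, going by these compounds alone, compound 3 gives 9020 nM, the first value at this position that is a number and not a limit. Isopropyl in place of 4-nitrophenyl, on a saturated chain carbon, two bonds along the chain from an oxygen next to a carbonyl group, therefore gives a readable change, an at least 2.2-fold lower number from compound 2 to compound 3 (0.34 log units; beyond the scatter). The comparison with the 3,4-dimethoxyphenyl compound gives an at least 1.6-fold lower number from compound 1 to compound 3 (0.22 log units; that floor lies within the scatter), so only the change from the 4-nitrophenyl compound is shown to exceed the scatter, while the step between the two limit compounds cannot be read.

As far as these compounds go, whether a longer chain, or a chain ending in an amine or a carboxylic acid, would lower the number further remains open. From the compounds shown here alone, both readable steps are floors, so their full sizes also remain open.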